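Swapping the Pendant Aryl Ring on a Sulfonamide Series

The source may hold more compounds than are shown below. What is called first, only, known or untested is meant among the compounds shown, and "the series" means these compounds.

Three compounds share one core and differ only in the group attached to the aromatic ring of the sulfonamide. In a functional assay on DLD-1 cells (Homo sapiens) for antiproliferative activity, read by CellTiter-Glo, with a stated time of 72 h (on this read-out higher numbers stand for weaker inhibition and lower numbers for stronger inhibition), compound 1 `CC1CCN(C2CCN(S(=O)(=O)c3cccc(Br)c3)CC2)CC1` gives 3.2 nM. Compound 2 `COc1ccccc1-c1cccc(S(=O)(=O)N2CCC(N3CCC(C)CC3)CC2)c1` gives 21 nM in this assay, and compound 3 `CC1CCN(C2CCN(S(=O)(=O)c3cccc(-c4ccccc4F)c3)CC2)CC1` gives 10 nM. Among these three numbers compound 3 holds the second highest, a step of a 3.1-fold higher number from compound 1 to compound 3 (0.49 log units; beyond the scatter) away from compound 1, and compound 2 sits a step of a 2.1-fold lower number from compound 2 to compound 3 (0.32 log units; beyond the scatter) above it.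

Compound 4 `Cc1ccc(-c2cccc(S(=O)(=O)N3CCC(N4CCC(C)CC4)CC3)c2)cc1` differs from compound 3 in one place: 4-methylphenyl in place of 2-fluorophenyl on an aromatic carbon. Going by the values given here, two measured steps bear on this change. Replacing the bromo of compound 1 with an aryl ring raised the number in both cases, a 6.6-fold higher number from compound 1 to compound 2 (0.82 log units; beyond the scatter) and a 3.1-fold higher number from compound 1 to compound 3 (0.49 log units; beyond the scatter), and the two aryl rings differed from each other by a 2.1-fold lower number from compound 2 to compound 3 (0.32 log units; beyond the scatter). Because compound 3 gives 10 nM with an aryl ring at this carbon and compound 4 also carries an aryl ring there, the number of compound 4 is expected to stay near that, with a step of a 1.5-fold higher number from compound 3 to compound 4 (0.18 log units; within the scatter) that may fall within the scatter. Compound 4 is therefore estimated at 15 nM, within a range from 5 nM to 45 nM.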

Compound 4, half-maximal inhibitory concentration: 11 nM
The estimate for compound 4 lay 1.4-fold (0.13 log units) above the measured number; the measured number falls inside the stated range.
By their numbers in this assay, from the lowest: compound 1; then compounds 3, 4 and 2 (each within the scatter of the next, the first and the last beyond it).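

Replacing the 2-fluorophenyl with 4-methylphenyl on this aromatic carbon gives, in this assay, a 1.1-fold higher number from compound 3 to compound 4 (0.04 log units; within the scatter), so changing both the ring's substituent and where it sits has no effect that can be told from the scatter. The 2-methoxyphenyl comparison gives a 1.9-fold lower number from compound 2 to compound 4 (0.28 log units; within the scatter), which also stays within the scatter, while the comparison with the bromo gives a 3.4-fold higher number from compound 1 to compound 4 (0.54 log units; beyond the scatter), making this the third aryl ring whose number stands above that of compound 1, with none of the compounds shown going against this. Nothing available explains this difference between the bromo and the aryl rings. The compounds shown leave open how 2-methylphenyl and 4-fluorophenyl would compare, which would separate the identity of the substituent from its place on the ring. Also open, from the compounds shown here alone, is whether a chloro or nitrile, or an aryl ring carrying an amine or carboxylic acid, would read closer to compound 1 or to the other aryl compounds.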